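Methyl xanthate replacing a methyl ether on a macrocyclic scaffold

The source may report more compounds than this note shows. Statements on the series, on what has been measured and on what is new or still open speak of the compounds shown alone.

Measured compounds:
Compound 1, `COC/C1=C/C[C@](C)(CCC=C(C)C)/C=C/[C@@H](OC(=O)C=C(C)C)[C@](C)(O)/C=C/C1=O`: 3850 nM
Compound 2, `CC(C)=CCC[C@]1(C)/C=C/[C@@H](OC(=O)C=C(C)C)[C@](C)(O)/C=C/C(=O)/C(COC(=O)c2ccc([N+](=O)[O-])cc2)=C\C1`: 570 nM

Both compounds were tested in a functional assay on SW480 cells (Homo sapiens) for antiproliferative activity, read by MTT assay, with a stated time of 48 h; a higher number here means a weaker inhibitor, a lower number a stronger inhibitor. Among the compounds with values here, of the two numbers known there, compound 1 gives the highest, so it is the weaker inhibitor of the pair; its nearest neighbour is compound 2, reached by the step of a 6.8-fold lower number from compound 1 to compound 2 (0.83 log units; beyond the scatter), in which a (4-nitrophenyl)carbonyl group stands in place of a methyl on an oxygen on a saturated carbon.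

The unmeasured compound 3, `CSC(=S)OC/C1=C/C[C@](C)(CCC=C(C)C)/C=C/[C@@H](OC(=O)C=C(C)C)[C@](C)(O)/C=C/C1=O`, alters the same position of compound 1: a group of 4 heavy atoms (2 carbon, 2 sulfur; no ring) in place of one carbon atom, on an oxygen on a saturated carbon

Within the data shown here, only the step from compound 1 to compound 2 touches the same oxygen, and there a larger group in place of the methyl lowered the number markedly. Compound 3 likewise carries a larger group in place of the methyl, though a different one, so a move in the same direction, smaller and less certain, seems the reasonable expectation.

For compound 3 the expected result in this assay is 1500 nM (range 500 nM to 4500 nM), which would be the expected step of a 2.6-fold lower number from compound 1 to compound 3 (0.41 log units; beyond the scatter).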

Compound 3, half-maximal inhibitory concentration: 390 nM
For compound 3 the middle estimate is 3.8-fold (0.59 log units) above the measured one; the measured number lies below the stated range.
By their numbers in this assay, from the lowest: compounds 3 and 2 (each within the scatter of the next); then compound 1.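

In this assay, replacing the methyl on this oxygen with a group of 4 heavy atoms (2 carbon, 2 sulfur; no ring) gives a 9.9-fold lower number from compound 1 to compound 3 (0.99 log units; beyond the scatter), so the earlier gain is not unique to the (4-nitrophenyl)carbonyl group. The two replacements sit together, with a 1.5-fold lower number from compound 2 to compound 3 (0.16 log units; within the scatter), which means that among these compounds neither an aromatic ring nor a nitrogen in the group is required for the lower number, as compound 3 carries neither. Nothing available here explains why two such different groups both lower the number.

The compounds shown leave open whether any group this elaborate is needed, since a plain acetyl group on this oxygen, or a free hydroxyl with only a hydrogen there, would show whether simply losing the methyl is enough. They also leave open whether the two sulfur atoms matter, a question that a methoxycarbonyl group, the all-oxygen counterpart of the new group, could help to answer.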